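Cyclopentylamino in Place of Allyloxy: Tolerance Expected Unchanged

A few compounds are considered here, and "the series" means these few. Any claim that something is new, unique, unknown or untested is made for them only; others in the source may bear on it.

Compound 1 `C=CCOc1nc(N)nc2c1ncn2/C=C1/CC1(CO)CO` was tested in an ADME assay on MOLT-3 cells (Homo sapiens) for cytotoxicity, with a stated time of 7 days; a lower number here means that less compound is tolerated, a higher number that more compound is tolerated. In this assay compound 1 gives > 20000 nM, which is a limit of the assay rather than a number. Compound 2 `CCCCCCCCOc1nc(N)nc2c1ncn2/C=C1/CC1(CO)CO` gives > 20000 nM, also a limit. Compound 3 `CCCSc1nc(N)nc2c1ncn2/C=C1/CC1(CO)CO` gives > 20000 nM, again a limit. Compound 4 `Nc1nc(NC2CCCC2)c2ncn(/C=C3/CC3(CO)CO)c2n1` differs from compound 1 by cyclopentylamino in place of allyloxy on an aromatic carbon. The measured steps a step that the two limits leave unreadable from compound 1 to compound 2, a step that the two limits leave unreadable from compound 1 to compound 3 and a step that the two limits leave unreadable from compound 2 to compound 3 cannot be read in size, since all three values sit at the limit of > 20000 nM in this assay, at which 3 of the 3 values shown sit. No change at this position has moved any compound off that limit, so for compound 4 a similar outcome is expected: compound 4 is estimated at 30000 nM, between 12000 nM and 80000 nM, a step that the limit leaves unreadable from compound 1 to compound 4 expected to be nothing beyond the scatter.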

Compound 4, half-maximal cytotoxic concentration: > 20000 nM
Compound 4 gave a limit, no number; the forecaster's own chance of this, stated with the estimate: 85%; the middle value does not contradict the limit.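

Compound 4 sits at the same assay limit as compound 1, compound 2 and compound 3, so no step among them can be read: the limit of > 20000 nM in this assay, at which 4 of the 4 values shown sit.

These compounds leave open whether tolerance in this assay truly differs among them, and by how much.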